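A few compounds are considered here, and "the series" means these few. Any claim that something is new, unique, unknown or untested is made for them only; others in the source may bear on it.

Measured compounds:
Compound 1, `COc1ccc(/C=C(\C(=O)c2ccc(Br)cc2)S(=O)(=O)c2ccc(Br)cc2)cc1`, gives 25000 nM in a functional assay on DU-145 cells (Homo sapiens) for inhibition, read by trypan blue exclusion, with a stated time of 96 h; a lower number here means a stronger inhibitor of growth, a higher number a weaker inhibitor of growth.
Compound 2, `COc1ccc(/C=C(\C(=O)c2ccc(Br)cc2)S(=O)(=O)c2ccc(Br)cc2)c(F)c1`, gives 10000 nM in this assay.
Compound 3, `O=C(/C(=C\c1ccc(F)cc1F)S(=O)(=O)c1ccc(Br)cc1)c1ccc(Br)cc1`, gives 7500 nM in this assay.

Compound 3 has the lowest number of the three, but its gap to compound 2 lies within the scatter, so the two cannot be told apart; compound 1 sits clearly higher, as a 3.3-fold lower number from compound 1 to compound 3 (0.52 log units; beyond the scatter) shows. Compound 4, `O=C(/C(=C\c1ccc(F)cc1)S(=O)(=O)c1ccc(Br)cc1)c1ccc(Br)cc1`, is not yet measured. It differs from compound 3 in one place: hydrogen in place of fluoro on an aromatic carbon. The same kind of change has already been made once, from compound 2 to compound 1: hydrogen in place of fluoro on an aromatic carbon, with the step of a 2.5-fold higher number from compound 2 to compound 1 (0.40 log units; beyond the scatter). The surroundings are not identical: in compound 3 the leaving fluoro stands meta to a fluoro group (1 heavy atom), whereas in compound 2 it stands meta to a methoxy group (2 heavy atoms). The two cores differ by fluoro in place of methoxy on an aromatic carbon, a change whose step was a 1.3-fold lower number from compound 2 to compound 3 (0.12 log units; within the scatter). A step of similar size is expected, a 2.3-fold higher number from compound 3 to compound 4 (0.36 log units; beyond the scatter), because the earlier change gave a 2.5-fold higher number from compound 2 to compound 1 (0.40 log units; beyond the scatter). Compound 4 is therefore estimated at 17000 nM, with a range from 8000 nM to 40000 nM.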

Compound 4, concentration for 50% growth inhibition: 4000 nM
Estimate against measurement, compound 4: 4.3-fold (0.63 log units) above; the whole stated range lies above it.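

On the core of compound 3, hydrogen in place of fluoro gives a 1.9-fold lower number from compound 3 to compound 4 (0.27 log units; within the scatter) and cannot be told from no change, so it does not repeat the step seen on the other core: the same change on two cores in this assay, a 2.5-fold higher number (0.40 log units; beyond the scatter) from compound 2 to compound 1 and a 1.9-fold lower number (0.27 log units; within the scatter) from compound 3 to compound 4, 4.7-fold (0.67 log units) apart, beyond the scatter of two such steps

Fluoro in place of methoxy also depends on its core, giving a 6.3-fold lower number from compound 1 to compound 4 (0.80 log units; beyond the scatter) when the ring carries no second fluoro, whereas the step is within the scatter when it does: the same change on two cores in this assay, a 1.3-fold lower number (0.12 log units; within the scatter) from compound 2 to compound 3 and a 6.3-fold lower number (0.80 log units; beyond the scatter) from compound 1 to compound 4, 4.7-fold (0.67 log units) apart, beyond the scatter of two such steps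

Both changes made at once give a 2.5-fold lower number from compound 2 to compound 4 (0.40 log units; beyond the scatter) and, taken together, these compounds show that a step measured on one core is a poor guide to the same step on another, but they do not show why, and a single pair of cores cannot tell how general this is.

From the compounds shown here alone, it remains open whether a chloro or methyl group at the place of the leaving fluoro, or an amine in place of the methoxy, would follow either step. Every compound shown also keeps both bromo groups, so whether these steps would hold on a core with other groups there is unknown too.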